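This account rests on a few compounds, and the source may have more. Where it says the series, first, only, none or still open, it means among the compounds named here.

Measured compounds in the series:

Compound 1 `O=C(CN1CCN(c2cccc(Cl)c2)CC1)N1CCN(c2nnc(-c3ccccc3)c(-c3ccccc3)n2)CC1`: in a functional assay on MCF7 cells (Homo sapiens) for cytotoxicity, read by MTT assay, with a stated time of 24 h (on this read-out lower numbers stand for stronger inhibition and higher numbers for weaker inhibition), compound 1 gives 56300 nM.
Compound 2 `COc1ccc(N2CCN(CC(=O)N3CCN(c4nnc(-c5ccccc5)c(-c5ccccc5)n4)CC3)CC2)cc1`: compound 2 gives only a limit of the assay, > 910000 nM.
Compound 3 `COc1ccc(-c2nnc(N3CCN(C(=O)CN4CCN(c5cccc(Cl)c5)CC4)CC3)nc2-c2ccc(OC)cc2)cc1`: compound 3 likewise gives only a limit of the assay, > 814000 nM.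

Compound 4 `COc1ccc(-c2nnc(N3CCN(C(=O)CN4CCN(c5ccc(OC)cc5)CC4)CC3)nc2-c2ccc(OC)cc2)cc1` is not yet measured. Between compound 1 and compound 2 the change is 4-methoxyphenyl in place of 3-chlorophenyl on an amine nitrogen in a ring, and it brought an at least 16-fold higher number from compound 1 to compound 2 (1.20 log units; beyond the scatter), so that compound 2 sits at a limit (the limit of > 910000 nM in this assay, at which 1 of the 3 values shown sits). Compound 3 and compound 4 differ by the same change, (4-methoxyphenyl in place of 3-chlorophenyl on an amine nitrogen in a ring), made on the same place word for word. How the core of compound 3 differs from the core of compound 1 is not broken down here. Compound 3 already sits at a limit (the limit of > 814000 nM in this assay, at which 1 of the 3 values shown sits), so the step made by the same change in this assay, which pushed compound 1 to a limit in compound 2, leaves little room for a measurable number in compound 4. Compound 4 is therefore expected to stay at or beyond the limit, with the estimated step that the limit leaves unreadable from compound 3 to compound 4, and its estimated value in this assay is 1500000 nM, between 500000 nM and 5000000 nM.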

Compound 4, half-maximal inhibitory concentration: > 821000 nM
Compound 4 was reported as a limit (the forecaster's own chance of this, stated with the estimate: 85%); the middle value lies beyond the limit too.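

In this assay, compound 3 and compound 4 are both reported only as limits of the assay, and the step from one to the other cannot be read. The compounds shown leave open whether 4-methoxyphenyl in place of 3-chlorophenyl changes the number on the core of compound 3 as it does on the core of compound 1.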